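Enlarging the sulfanyl group from methyl to tert-butyl

The source may hold more compounds than are shown below. What is called first, only, known or untested is meant among the compounds shown, and "the series" means these compounds.

For the measured compounds named here, compound 2 `CSc1cc(C)c(C(=O)N=C(N)N)cc1S(C)(=O)=O` gives 6 nM in a functional assay for inhibition of sodium/hydrogen exchanger (Oryctolagus cuniculus) (a higher number here means a weaker inhibitor, a lower number a stronger inhibitor), the lower of the two numbers known so far. Compound 1 `Cc1cc(-c2ccccc2)c(S(C)(=O)=O)cc1C(=O)N=C(N)N` gives 19 nM in this assay. Going by the values given here, the single measured step, a 3.2-fold lower number from compound 1 to compound 2 (0.50 log units; beyond the scatter), concerns a methylsulfanyl group in place of a phenyl group on the shared core. Compound 3 `Cc1cc(SC(C)(C)C)c(S(C)(=O)=O)cc1C(=O)N=C(N)N` differs from compound 2 by tert-butyl in place of methyl on a sulfur. Among the compounds with values here, no measured step bears directly on a change of this kind: the step from compound 1 to compound 2 exchanges one whole substituent for another, whereas here the sulfur stays in place and only the group attached to it grows. Compound 3 is therefore expected to give a number close to that of compound 2, with a 1.7-fold higher number from compound 2 to compound 3 (0.22 log units; within the scatter) held within or near the scatter, and with wider uncertainty than a guided step would carry. The estimate for compound 3 in this assay is 10 nM, within a range from 3 nM to 40 nM.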

Compound 3, half-maximal inhibitory concentration: 22 nM
Compound 3: middle estimate off by 2.2-fold (0.34 log units), on the low side; the measured number falls inside the stated range.
By their numbers in this assay, from the lowest: compound 2; then compounds 1 and 3 (each within the scatter of the next).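

In this assay the group on the sulfur proves not to be a neutral passenger: with the sulfur kept in place, tert-butyl instead of methyl gives (a 3.7-fold higher number from compound 2 to compound 3 (0.56 log units; beyond the scatter)) and leaves compound 2 with the lowest of the three numbers. The exchange of phenyl for (tert-butyl)sulfanyl gives (a 1.2-fold higher number from compound 1 to compound 3 (0.06 log units; within the scatter)), so the advantage that methylsulfanyl showed over phenyl is absent with the larger group on the sulfur. Nothing available explains the rise from methyl to tert-butyl.

The compounds shown contain no group of intermediate size on this sulfur, so it remains open whether ethyl or isopropyl would stay close to methyl or already resemble tert-butyl. As far as these compounds go, it also remains open whether the sulfur itself matters, as no methoxy group or amine stands in its place.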